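The source may report more compounds than this note shows. Statements on the series, on what has been measured and on what is new or still open speak of the compounds shown alone.

Measured so far in a functional assay on NCI-H460 cells (Homo sapiens) for inhibition (a higher number here means a weaker inhibitor of growth, a lower number a stronger inhibitor of growth), for this series

- compound 1 `Nc1ccc(-c2nc3ccc(F)cc3s2)cc1I` gives > 100000 nM as a limit of the assay, not a number
- compound 2 `Cc1cc(-c2nc3c(F)cccc3s2)ccc1N` gives 1000 nM
- compound 3 `Nc1ccc(-c2nc3cc(F)ccc3s2)cc1Br` gives 110 nM

Compound 2 (1000 nM) holds the higher of the two numeric values. Compound 3 (110 nM) lies lower, and that gap is beyond the scatter.

The next member is compound 4 `Cc1cc(-c2nc3ccccc3s2)ccc1N` with hydrogen in place of fluoro on an aromatic carbon of compound 2 (hydrogen in place of fluoro on an aromatic carbon). For the measured compounds named here, no measured pair isolates this change, and every measured compound carries a fluoro group. The expectation in this assay is therefore loose: a modest step toward a lower number, around the edge of the scatter, with compound 3 (110 nM) showing that lower values occur in the series. The expected change is a 2.0-fold lower number from compound 2 to compound 4 (0.30 log units; within the scatter) and remains tentative. For compound 4 the estimated value is 500 nM with an expected range from 60 nM to 5000 nM in this series.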

Compound 4, concentration for 50% growth inhibition: 29500 nM
Compound 4: the middle estimate sits 59-fold (1.77 log units) below what was measured; the whole stated range lies below it.
By their numbers in this assay, from the lowest: compound 3; then compound 2; then compound 4. At a limit, above all of these: compound 1.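

In this assay, a 30-fold higher number from compound 2 to compound 4 (1.47 log units; beyond the scatter) gives the series its first reading of a single change: hydrogen in place of fluoro on an aromatic carbon, ortho to a fused ring and meta to a fused ring. The fluoro group at this position therefore carries much of the growth inhibition seen with compound 2, and losing that one atom moves the number well beyond the scatter toward weaker inhibition. Compound 4 still gives a numeric reading, so the size of this step is not cut off by the ceiling of the assay: the limit of > 100000 nM in this assay, at which 1 of the 4 values shown sits.

Going by these compounds, whether chloro or methoxy on the same carbon would keep the activity of compound 2 remains open. So does whether removing fluoro would have a similar effect in compound 3, with its bromo group, or in compound 1, with its iodo group.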